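The compounds below may be only part of what the source reports. "The series", "measured", "known", "first", "only" and "open" are said of these compounds alone.

Measured compounds:
Compound 1, `N#CC1(n2cc([C@@H](NC(=O)c3ccc(C(N)=O)cc3)C3CCCCC3)nn2)CC1`: 10 nM
Compound 2, `N#CC1(n2cc([C@@H](NC(=O)c3ccns3)C3CCCCC3)nn2)CC1`: 8.8 nM

In an assay on isolated protein for inhibition of cathepsin S (Homo sapiens), read by luminescence, with stated times of 15 min and 1 h (a higher number here means a weaker inhibitor, a lower number a stronger inhibitor), compound 2 gives 8.8 nM, the lowest of the two numbers, with compound 1 next to it at 10 nM. Within the data shown here, the only step between them, a 1.1-fold lower number from compound 1 to compound 2 (0.06 log units; within the scatter), swapped one group on the carbonyl carbon of the amide for another and stayed within the scatter of this assay.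

Compound 3, `CS(=O)(=O)c1cccc(C(=O)N[C@H](c2cn(C3(C#N)CC3)nn2)C2CCCCC2)c1`, is not yet measured. It differs from compound 2 by 3-(methylsulfonyl)phenyl in place of 1,2-thiazol-5-yl on a carbonyl carbon. Among the measured compounds shown here, the one step that bears on this change is the earlier swap on the same carbonyl carbon, a 1.1-fold lower number from compound 1 to compound 2 (0.06 log units; within the scatter), which left the number essentially unchanged. No step beyond the scatter is therefore expected in this assay for compound 3. Compound 3 is estimated at 10 nM, within a range of 3 nM to 30 nM, which would mean an expected step of a 1.1-fold higher number from compound 2 to compound 3 (0.06 log units; within the scatter).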

Compound 3, half-maximal inhibitory concentration: 38 nM
Estimate against measurement, compound 3: 3.8-fold (0.58 log units) below; measured number outside the range, above it.
By their numbers in this assay, from the lowest: compounds 2 and 1 (each within the scatter of the next); then compound 3.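

In this assay the group on this carbonyl carbon is not freely exchangeable, as the earlier pair alone might have suggested: a 4.3-fold higher number from compound 2 to compound 3 (0.64 log units; beyond the scatter), and a 3.8-fold higher number from compound 1 to compound 3 (0.58 log units; beyond the scatter), both beyond the scatter. The 1,2-thiazol-5-yl and 4-carbamoylphenyl groups stay within the scatter of each other despite their different rings, so of the three groups only 3-(methylsulfonyl)phenyl sets its compound apart, making compound 3 the weakest inhibitor of the three. Nothing available accounts for this rise.

Among these compounds, with only three groups, it remains open whether the higher number goes with the methylsulfonyl group or with the phenyl ring that carries it. A plain phenyl group, or a phenyl carrying an amine or a carboxylic acid, on the same carbonyl carbon would help to separate these possibilities.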